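From Phenyl to an Amide-Bearing Side Chain

The compounds below may be only part of what the source reports. "The series", "measured", "known", "first", "only" and "open" are said of these compounds alone.

Measured so far:
compound 1 `CCOC(=O)C1=Cc2ccccc2OC1(OCc1cn(-c2ccccc2)nn1)C(F)(F)F` — > 150000 nM
compound 2 `CCOC(=O)C1=Cc2ccccc2OC1(OCc1cc(-c2ccc(Cl)cc2)no1)C(F)(F)F` — 18200 nM

In a functional assay on DU-145 cells (Homo sapiens) for inhibition, read by MTT assay, with a stated time of 24 h (a lower number here means a stronger inhibitor, a higher number a weaker inhibitor), compound 1 reaches only a limit of the assay, > 150000 nM, so no number is known for it (the limit of > 150000 nM in this assay, at which 1 of the 2 values shown sits). In this assay compound 2 gives 18200 nM. Compound 3 `CCOC(=O)C1=Cc2ccccc2OC1(OCc1cn(CC(=O)Nc2ccc(I)cc2Cl)nn1)C(F)(F)F` differs from compound 1 by ((2-chloro-4-iodophenyl)carbamoyl)methyl in place of phenyl on an aromatic nitrogen. With no measured step of this kind shown, the direction is open; the change is expected to give a stronger inhibitor, a step beyond the scatter, meaning an estimated step of an at least 3.7-fold lower number from compound 1 to compound 3 (0.57 log units; beyond the scatter). Compound 3 is therefore estimated at 40000 nM, within 10000 nM to 150000 nM.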

Compound 3, half-maximal inhibitory concentration: 24400 nM
For compound 3 the middle estimate is 1.6-fold (0.21 log units) above the measured one; the range from low to high includes it.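

Putting ((2-chloro-4-iodophenyl)carbamoyl)methyl in place of phenyl on the aromatic nitrogen brings an at least 6.1-fold lower number from compound 1 to compound 3 (0.78 log units; beyond the scatter). This position therefore accepts a larger group carrying an amide hydrogen, and inhibition becomes measurable. The size of the step is only a bound, since it starts from a limit: the limit of > 150000 nM in this assay, at which 1 of the 3 values shown sits.

The compounds shown do not separate the contribution of the amide from that of the chlorine and iodine on the ring. As far as these compounds go, how a plain phenyl amide, a carboxylic acid or an amine would behave at this position stays open.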